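Compound 3 and the cytotoxicity limit

This account rests on a few compounds, and the source may have more. Where it says the series, first, only, none or still open, it means among the compounds named here.

Measured in an ADME assay on BJ cells (Homo sapiens) for cytotoxicity, with a stated time of 72 h; a higher number here means that more compound is needed for the effect, a lower number that less compound is needed:
compound 1 `C=C[C@@](C)(/C=C/c1ccc(Nc2cc(F)cc(F)c2)cc1)CCC=C(C)C`: > 36600 nM
compound 2 `C=C[C@@](C)(/C=C/c1ccc(Nc2cc(F)c(F)cc2F)cc1)CCC=C(C)C`: > 36600 nM

Compound 1 stands only at a limit, > 36600 nM, and not at a number. Compound 2 likewise gives only a limit, > 36600 nM. Both compounds therefore sit at the same ceiling: the limit of > 36600 nM in this assay, at which 2 of the 2 values shown sit.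

The next compound, compound 3 `C=C[C@@](C)(/C=C/c1ccc(-c2ccc(Cl)cc2)cc1)CCC=C(C)C`, has not yet been measured. It carries 4-chlorophenyl in place of (3,5-difluorophenyl)amino on an aromatic carbon, para to a large group: 4-chlorophenyl in place of (3,5-difluorophenyl)amino on an aromatic carbon.

Among the compounds with values here, only one measured step bears on this change, and it bears weakly. That step is a step that the two limits leave unreadable from compound 1 to compound 2, and it alters only the ring on the nitrogen, so it offers no size to carry over. Within the data shown here, the data show no compound with a number in this assay, and they show no measured loss of the nitrogen link. No clear move in either direction can be argued, so compound 3 is expected to stay close to the same limit, and it may well report only a limit. The expected step is an at least 1.1-fold lower number from compound 1 to compound 3 (0.04 log units; that floor lies within the scatter). The estimate for compound 3 is 33000 nM, with an expected range from 14000 nM to 60000 nM.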

Compound 3, half-maximal effective concentration: > 36600 nM
Compound 3 was reported as a limit; the forecaster's own chance of this, stated with the estimate: 65%; at least 1.1-fold (0.04 log units) between middle value and limit.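

Compound 3 also gives only a limit in this assay, so the change from compound 1 to compound 3 cannot be read as a step and has no size: the limit of > 36600 nM in this assay, at which 3 of the 3 values shown sit.

The compounds shown leave open how far each one lies beyond that limit, and whether 4-chlorophenyl in place of (3,5-difluorophenyl)amino changes the half-maximal effective concentration at all.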